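The compounds below may be only part of what the source reports. "The series", "measured", "known", "first", "only" and "open" are said of these compounds alone.

In a functional assay on NALM-6 cells (Homo sapiens) for cytotoxicity, with a stated time of 72 h (on this read-out lower numbers stand for an effect already at smaller amounts and higher numbers for an effect only at larger amounts of compound), compound 1 (`C=C[C@@](C)(/C=C/c1ccc(OCc2ccccc2)cc1)CCC=C(C)C`) gives (> 43400 nM), which is a limit of the assay and not a number. Compound 2 (`C=C[C@@](C)(/C=C/c1ccc(Nc2ccc(OC(F)(F)F)cc2)cc1)CCC=C(C)C`) gives (> 43400 nM), and this too is a limit. Compound 2 therefore has no number of its own, and the record for both compounds is the same (the limit of > 43400 nM in this assay, at which 2 of the 2 values shown sit). Going by the values given here, no measured step between two compounds is available to show how far a single change can move this read-out.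

Compound 3 (`C=C[C@@](C)(/C=C/c1ccc(Nc2ccc(F)cc2)cc1)CCC=C(C)C`) differs from compound 2 in one place, with fluoro in place of trifluoromethoxy on an aromatic carbon, para to a large group (fluoro in place of trifluoromethoxy on an aromatic carbon). Given compound 2 at (> 43400 nM), no step beyond the scatter is expected in this assay and no direction can be favoured. The expected change is small (a number no higher from compound 2 to compound 3 (the limit leaves the size open)). Compound 3 is estimated at (43400 nM), with an expected range from (15000 nM) to (60000 nM), and the assay may well report only a limit again.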

Compound 3, half-maximal effective concentration: > 43400 nM
Compound 3: no number, only a limit; the forecaster's own chance of this, stated with the estimate: 75%; the middle value sits exactly at the limit.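

Compound 3 also ends at a limit, so no step can be read from compound 2 to compound 3 or from compound 1 to compound 3: the limit of > 43400 nM in this assay, at which 3 of the 3 values shown sit.

The compounds shown leave open how fluoro and trifluoromethoxy compare in this assay, and whether any change to the shared core would give a number there at all.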